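The source may report more compounds than this note shows. Statements on the series, on what has been measured and on what is new or still open speak of the compounds shown alone.

Measured compounds: compound 1 `CC(=O)c1cc2ccc(OCCCCCn3cc(CNC(=O)CCCCC4CCSS4)nn3)cc2oc1=O` gives 20.8% in a functional assay on PC-12 cells (Rattus norvegicus) for cytotoxicity, read by MTT assay, with stated times of 3 h and 2 h, tested at 10 uM; on this read-out lower numbers stand for a weaker effect and higher numbers for a stronger effect at the one concentration tested; compound 2 `O=C(CCCCC1CCSS1)NCc1cn(CCCCCOc2ccc3cc(-c4ccccc4)c(=O)oc3c2)nn1` gives 26.3% in this assay.

Compound 2 stands highest of the two numbers, with compound 1 nearest, the step being a number 5.5 percentage points higher from compound 1 to compound 2 (within the scatter), so the two compounds cannot be told apart on these numbers. Compound 3 `O=C(CCCCC1CCSS1)NCc1cn(CCCCCOc2ccc3cc(-c4ccc(Cl)c(Cl)c4)c(=O)oc3c2)nn1` differs from compound 2 in one place: 3,4-dichlorophenyl in place of phenyl on an aromatic carbon. Within the data shown here, the only measured step, phenyl in place of acetyl on an aromatic carbon, is a number 5.5 percentage points higher from compound 1 to compound 2 (within the scatter) and touches the same aromatic carbon that now carries 3,4-dichlorophenyl, but it is a different change and bears on the present one only loosely. Nothing measured here separates a phenyl from a 3,4-dichlorophenyl at that position. Compound 3 is therefore expected to give a step of a number 3.7 percentage points higher from compound 2 to compound 3 (within the scatter) in this assay, that is, none beyond the scatter. The estimate for compound 3 is 30%, with a range from 14% to 48%.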

Compound 3, a percentage reported as activity, at one concentration (the size of the read-out at that concentration, not a potency): 59.4%
Compound 3: the middle estimate sits 29.4 percentage points below what was measured, and the stated range ends below it.
By their numbers in this assay, from the lowest: compounds 1 and 2 (each within the scatter of the next); then compound 3.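

In this assay, the aromatic carbon on the shared core proves sensitive to what the attached phenyl carries: replacing phenyl with 3,4-dichlorophenyl gives a number 33.1 percentage points higher from compound 2 to compound 3 (beyond the scatter). The replacement of acetyl with 3,4-dichlorophenyl at the same carbon gives a number 38.6 percentage points higher from compound 1 to compound 3 (beyond the scatter), whereas phenyl in place of acetyl gave only a number 5.5 percentage points higher from compound 1 to compound 2 (within the scatter), so among these compounds a step beyond the scatter appears only with the two chlorine atoms present. Nothing available accounts for why this change has so large an effect.

The compounds shown leave open whether a phenyl bearing a single chlorine would give a step of this size, or whether a methoxy group or an amine on that phenyl would do so. Also open, going by these compounds, is whether the step would persist with a longer chain elsewhere in the molecule.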